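The source may report more compounds than this note shows. Statements on the series, on what has been measured and on what is new or still open speak of the compounds shown alone.

Of the compounds shown here, two have measured values so far, and both carry a (piperidin-4-yl)oxy group: compound 1 (`CC(C)(C)c1cc(NC(=O)Nc2ccc(NC(=O)c3ccc(OC4CCNCC4)cn3)cc2)no1`) and compound 2 (`CC(C)(C)c1cc(NC(=O)Nc2ccc(NC(=O)c3cc(OC4CCNCC4)ccn3)cc2)no1`). In an in vivo ADME assay on the whole organism (plasma, strain Sprague-Dawley) for pharmacokinetics, with Rattus norvegicus as the target, read by LC-MS, at a dose of 10 mg/kg by the oral route (a lower number here means that a smaller share of the oral dose reaches the circulation, a higher number that a larger share of the oral dose reaches the circulation), compound 1 gives 1%. Compound 2 gives 3% in this assay, which places it within the usual scatter of compound 1, so the two cannot be ranked.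

Compound 3 (`Cc1ccnc(C(=O)Nc2ccc(NC(=O)Nc3cc(C(C)(C)C)on3)cc2)c1`) differs from compound 2 by one change: methyl in place of (piperidin-4-yl)oxy on an aromatic carbon, opposite the ring nitrogen (methyl in place of (piperidin-4-yl)oxy on an aromatic carbon). For the measured compounds named here, no measured step isolates this change, and the data contain no compound with a methyl at this place, so any step size remains an expectation. With compound 2 at 3%, little room remains for a fall, so a moderate upward step, probably beyond the scatter, is expected in this assay. The expected change is a number 15 percentage points higher from compound 2 to compound 3 (beyond the scatter). Compound 3 is estimated at 18%, with an expected range of 4% to 40%.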

Compound 3, oral bioavailability: 4%
Beside the measured number, compound 3's estimate is 14 percentage points above it; the range from low to high includes it.
By their numbers in this assay, from the lowest: compounds 1, 2 and 3 (each within the scatter of the next).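

Replacing (piperidin-4-yl)oxy with methyl on an aromatic carbon, opposite the ring nitrogen, gives a number 1 percentage points higher from compound 2 to compound 3 (within the scatter) in this assay. Compounds 1 and 2 both carry the (piperidin-4-yl)oxy group, so they could not show what its absence does; this pair shows that, at this place, a compound without that group, its six-membered non-aromatic ring or its hydrogen-bond donor cannot be told apart from one with them in this read-out. No measurement at hand bears on why the two compounds read alike.

The compounds shown leave open whether a different group at this place, such as a primary amine, a carboxylic acid or a longer alkyl chain, would give a number beyond the scatter of compound 2, and whether methyl would read the same at the place the group holds in compound 1. They also leave open whether a change elsewhere in the shared core would move the read-out more than either change at this place.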